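Mirror Image of a Compound at the Assay Floor

A few compounds are considered here, and "the series" means these few. Any claim that something is new, unique, unknown or untested is made for them only; others in the source may bear on it.

Compound 1 `O=C(NO)c1cccc(-c2cn([C@@H]3C[C@@H](CO)N(Cc4ccccc4)C3)nn2)c1` was tested in an assay on Sf9 cells for inhibition of histone deacetylase 11 (Homo sapiens), read by fluorescence, tested at 0.5 uM; on this read-out lower numbers stand for less inhibition and higher numbers for more inhibition at the one concentration tested (going by the name of the read-out). In this assay compound 1 reaches only the limit of the measurement, < 10%, so no number is known for it. Compound 2 `O=C(NO)c1ccc(-c2cn([C@@H]3C[C@@H](CO)N(Cc4ccccc4)C3)nn2)cc1`, a close relative, also sits at the limit in this assay with < 10%. Compound 3 `O=C(/C=C/c1cn([C@H]2C[C@@H](C(=O)O)N(CCCc3ccccc3)C2)nn1)NO` is the only one of the three with a numerical result, giving 29% in this assay. The picture so far is dominated by the limit of < 10% in this assay, at which 2 of the 3 values shown sit.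

For the measured compounds named here, compound 4 `O=C(NO)c1cccc(-c2cn([C@H]3C[C@H](CO)N(Cc4ccccc4)C3)nn2)c1` has not yet been measured. the two compounds have the same atoms and bonds and differ only in configuration as drawn: 2 of 2 stereo elements differ (all stereocentres are inverted: mirror images); a stereocentre at a saturated ring carbon is drawn R in compound 1 and S in compound 4; a stereocentre at a saturated ring carbon is drawn S in compound 1 and R in compound 4 No measured pair differs in configuration alone, so the size of such a step cannot be read from what has been measured, and compound 1 offers only a limit as a starting point. Compound 4 is therefore expected to stay close to the floor, with the step from compound 1 estimated as a number at least 2 percentage points higher from compound 1 to compound 4 (that floor lies within the scatter), not clearly beyond the scatter. For compound 4 the estimate in this assay is 12%, with a range from 3% to 35%.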

Compound 4, a percentage reported as inhibition, at one concentration (the size of the read-out at that concentration, not a potency): < 10%
Compound 4 ended at the assay's limit; the forecaster's own chance of this, stated with the estimate: 55%; middle value at least 2 percentage points away from the limit.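

No step can be read from compound 1 to compound 4: both mirror images stand at a limit in this assay, not at a number. The compounds shown leave open whether inverting the configuration changes the inhibition at all.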